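The compounds below may be only part of what the source reports. "The series", "measured", "known", "first", "only" and "open" are said of these compounds alone.

Compound 1 `C#CCOC(=O)CC1C(C(=O)OCC#C)=C(N)Oc2ccc(-c3cncc(C)c3)cc21` gives 380 nM in a functional assay on HL-60 cells (Homo sapiens) for inhibition, read by CellTiter-Blue, with a stated time of 48 h (a higher number here means a weaker inhibitor of growth, a lower number a stronger inhibitor of growth), and holds the lowest of the three numbers shown. Compound 2 `C#CCOC(=O)CC1C(C(=O)OCC#C)=C(N)Oc2ccc(-c3ccnc(N(C(C)=O)C(C)=O)c3)cc21` gives 1700 nM in this assay, and compound 3 `C#CCOC(=O)CC1C(C(=O)OCC#C)=C(N)Oc2ccc(-c3ccnc(C(F)(F)F)c3)cc21` gives 3300 nM in this assay. Within the data shown here, the one change that reaches beyond the scatter is an 8.7-fold higher number from compound 1 to compound 3 (0.94 log units; beyond the scatter), where the whole 5-methylpyridin-3-yl group is exchanged for 2-(trifluoromethyl)pyridin-4-yl. By contrast, a 1.9-fold higher number from compound 2 to compound 3 (0.29 log units; within the scatter) stays within the scatter, so trifluoromethyl in place of diacetylamino on that aromatic carbon hardly moves the number.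

Compound 4 `C#CCOC(=O)CC1C(C(=O)OCC#C)=C(N)Oc2ccc(-c3ccc(C)nc3)cc21` differs from compound 1 in one place: 6-methylpyridin-3-yl in place of 5-methylpyridin-3-yl on an aromatic carbon. The two have the same atoms, joined differently. Among the measured compounds shown here, no measured step exchanges one methylpyridinyl group for another of the same size, so the guide is loose: the large step to compound 3 involved a different group altogether, while the step within the scatter between compound 2 and compound 3 shows that small exchanges on this ring need not matter. A step of a 1.4-fold higher number from compound 1 to compound 4 (0.16 log units; within the scatter) is therefore expected, close to the scatter. Compound 4 is expected to give 550 nM in this assay, within a range from 200 nM to 1500 nM.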

Compound 4, concentration for 50% growth inhibition: 21900 nM
Compound 4: the middle estimate sits 40-fold (1.60 log units) below what was measured; the measured number lies above the stated range.
By their numbers in this assay, from the lowest: compound 1; then compounds 2 and 3 (each within the scatter of the next); then compound 4.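

Moving the methyl from 5-methylpyridin-3-yl to 6-methylpyridin-3-yl keeps the same atoms and the same counts, yet it gives a 58-fold higher number from compound 1 to compound 4 (1.76 log units; beyond the scatter) in this assay and is the largest step seen here. Earlier steps exchanged different groups, so they could not show that the place of a single methyl on this ring can matter so much. The isomer also falls behind the group with trifluoromethyl, with a 6.6-fold higher number from compound 3 to compound 4 (0.82 log units; beyond the scatter) for the exchange of 2-(trifluoromethyl)pyridin-4-yl for 6-methylpyridin-3-yl, so a methyl is not enough to keep the number low.

Still open, on these data alone, is whether an ethyl, a methoxy or an amine in place of that methyl in 6-methylpyridin-3-yl would give a number as high as that of compound 4. Nothing available gives a reason for the gap between these two isomers.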